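This account rests on a few compounds, and the source may have more. Where it says the series, first, only, none or still open, it means among the compounds named here.

In an ADME assay on RAW264.7 cells (Mus musculus) for cytotoxicity, read by MTT assay (on this read-out higher numbers stand for weaker inhibition and lower numbers for stronger inhibition), compound 1 (`Cc1ccc(C(=O)/C=C/C=C/c2ccccc2)s1`) gives > 100000 nM as a limit and not a number. Compound 2 (`COc1ccc(/C=C/C=C/C(=O)c2ccccc2)cc1`) gives > 100000 nM as a limit too. Compound 3 (`COc1ccc(/C=C/C=C/C(=O)c2ccc(C)s2)cc1`) has no single number here, its entry being "not determined" (no result reported) and its nearest guide being the limit of > 100000 nM in this assay, at which 2 of the 3 values shown sit, for now. Compound 4 (`COc1ccc(/C=C/C=C/C(=O)c2ccc[nH]2)cc1`), still unmeasured, carries 1H-pyrrol-2-yl in place of 5-methylthiophen-2-yl on a carbonyl carbon, a change counted as 1H-pyrrol-2-yl in place of 5-methylthiophen-2-yl on a carbonyl carbon in the two structures. For the measured compounds named here, no measured step gives the size of this change. Resting on compound 2 at > 100000 nM as a limit, no step beyond the usual scatter is expected in this assay for this change. For compound 4 the estimated value is 100000 nM with an expected range from 30000 nM to 300000 nM in this measurement.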

Compound 4, half-maximal inhibitory concentration: > 100000 nM
Compound 4: no number, only a limit (the forecaster's own chance of this, stated with the estimate: 70%); the middle value lies on the limit itself.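

For the compounds shown here, compound 2 and compound 4 each give only a limit and not a number, so no step between them can be read. Whether changing the group on the carbonyl carbon alters cytotoxicity stays open, with the values shown resting on one mark: the limit of > 100000 nM in this assay, at which 3 of the 4 values shown sit.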